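Swapping methyl for fluoro on the anilino ring

A few compounds are considered here, and "the series" means these few. Any claim that something is new, unique, unknown or untested is made for them only; others in the source may bear on it.

Measured so far:
compound 1 `COc1cc(C(=O)c2sc(Nc3ccc(C)cc3)nc2N)cc(OC)c1OC`: 21 nM
compound 2 `COc1ccccc1C(=O)c1sc(Nc2ccccc2)nc1N`: 1300 nM
compound 3 `COc1ccc(Nc2nc(N)c(C(=O)c3cccc(OC)c3)s2)cc1`: 4 nM

Of the compounds shown here, three sharing a core have been tested in a functional assay on MOLT-4 cells (Homo sapiens) for antiproliferative activity, read by cell counting, with a stated time of 2 days; a higher number here means a weaker inhibitor, a lower number a stronger inhibitor. Compound 1 gives 21 nM and stands second highest of the three numbers. Compound 3 gives 4 nM, a lower number that lies beyond the scatter of compound 1, while compound 2 gives 1300 nM, a far higher number. No two of these compounds differ in only one place, so no single step is drawn among them.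

Compound 4 `COc1cc(C(=O)c2sc(Nc3ccc(F)cc3)nc2N)cc(OC)c1OC` is the next one to be measured in this assay. It differs from compound 1 in one place: fluoro in place of methyl on an aromatic carbon, so that a (4-methylphenyl)amino group becomes a (4-fluorophenyl)amino group. Going by the values given here, nothing among the measured compounds isolates the effect of this exchange. With no guide of that kind, compound 4 is expected to stay near compound 1, with a step of a 1.2-fold higher number from compound 1 to compound 4 (0.08 log units; within the scatter) that is within the scatter. The estimate for compound 4 is 25 nM with a range from 8 nM to 80 nM.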

Compound 4, half-maximal inhibitory concentration: 280 nM
Compound 4: middle estimate off by 11-fold (1.05 log units), on the low side; measured number outside the range, above it.
By their numbers in this assay, from the lowest: compound 3; then compound 1; then compound 4; then compound 2.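

Fluoro in place of methyl on this aromatic carbon, para to a large group, gives a 13-fold higher number from compound 1 to compound 4 (1.12 log units; beyond the scatter) in this assay. The earlier compounds shown here differ from one another in more than one place, so they could not isolate this position; this pair shows that it is sensitive, since exchanging one heavy atom for another, with no change in hydrogen-bond donors, acceptors or net charge, moves the number beyond the scatter. Nothing measured here explains why so small an exchange has so large an effect.

On these data alone, how chloro, ethyl or an amine would read at this same place, with the rest of compound 1 kept, remains open. As far as these compounds go, it is also open whether this exchange would give a step of similar size with a different group on the carbonyl.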